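This account rests on a few compounds, and the source may have more. Where it says the series, first, only, none or still open, it means among the compounds named here.

Compound 3 `O=C(NO)c1ncccc1Cl` is a compound that tolerates 800000 nM in an ADME assay on Huh-7 cells (Homo sapiens) for cytotoxicity, read by MTT assay, with a stated time of 72 h; a higher number here means that more compound is tolerated, a lower number that less compound is tolerated. Its number is the largest of the three measured, although neither of the other two stands beyond the scatter from it: compound 1 `O=C(NO)c1ccccn1` gives 710000 nM in this assay, and compound 2 `O=C(NO)c1cccnc1` gives 450000 nM. Within the data shown here, the one measured step at the same place on the ring, the change of hydrogen to chloro, moved the number a 1.1-fold higher number from compound 1 to compound 3 (0.05 log units; within the scatter).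

Compound 4 `COc1cccnc1C(=O)NO` differs from compound 3 as follows: methoxy in place of chloro on an aromatic carbon. Among the measured compounds shown here, no measured pair shows a methoxy taking the place of a chloro, so the only guidance is the step from compound 1 to compound 3, which stayed within the scatter. On that basis compound 4 is expected to show a step of a 1.1-fold lower number from compound 3 to compound 4 (0.03 log units; within the scatter), that is, none beyond the scatter. The estimate for compound 4 is therefore 750000 nM, with a range from 350000 nM to 1500000 nM.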

Compound 4, half-maximal cytotoxic concentration: 880000 nM
Beside the measured number, compound 4's estimate is 1.2-fold (0.07 log units) below it, and the stated range covers the measured number.
By their numbers in this assay, from the lowest: compounds 2, 1, 3 and 4 (each within the scatter of the next).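

In this assay the place that holds chloro in compound 3 also takes methoxy, with a step of a 1.1-fold higher number from compound 3 to compound 4 (0.04 log units; within the scatter) even though the entering group brings two heavy atoms and a hydrogen-bond acceptor where chloro has one heavy atom and none. Measured against hydrogen at the same place, methoxy gives a step of a 1.2-fold higher number from compound 1 to compound 4 (0.09 log units; within the scatter) so hydrogen, chloro and methoxy at this place now stand within the scatter of one another, and the earlier pair alone could show that only for hydrogen and chloro. Nothing available accounts for these small steps.

From the compounds shown here alone, whether an amine, a carboxylic acid or a longer chain at this place would give a step beyond the scatter remains open. So does the effect of any of these groups at the other aromatic carbons of the shared core.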